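Chloro Substitution on Two Related Cores

A few compounds are considered here, and "the series" means these few. Any claim that something is new, unique, unknown or untested is made for them only; others in the source may bear on it.

Compound 1, `N=c1c(=O)[nH]nc2n1CCN2c1cccc(Cl)c1`: 3% in a functional assay on T47D cells (Homo sapiens) for cytotoxicity, with a stated time of 72 h, tested at 10 ug/mL; on this read-out higher numbers stand for a stronger effect at the one concentration tested and lower numbers for a weaker effect
Compound 2, `N/N=C1\NCCN1c1ccccc1`: 0% in this assay
Compound 3, `N=c1c(=O)[nH]nc2n1CCN2c1ccccc1`: 0% in this assay

All three measured compounds give low readings in this assay. From compound 3 to compound 1 the change is chloro in place of hydrogen on an aromatic carbon, and the step is a number 3 percentage points higher from compound 3 to compound 1 (within the scatter). Compound 2 rests on a different core than compound 3; the difference between the two cores is not broken down here, and their values in this assay are level at the digits shown.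

Compound 4, `N/N=C1\NCCN1c1cccc(Cl)c1`, is not yet measured. It differs from compound 2 by chloro in place of hydrogen on an aromatic carbon. Among the measured compounds shown here, this is the same kind of change as the one from compound 3 to compound 1: in both the chloro enters on an aromatic carbon of a six-membered aromatic ring of carbon only, but in compound 1 it sits meta to a large group, whereas in compound 4 it sits meta to a group of 7 heavy atoms. Since the earlier step, a number 3 percentage points higher from compound 3 to compound 1 (within the scatter), stayed within the scatter, the step from compound 2 to compound 4 in this assay is expected to be similarly small, a number 2 percentage points higher from compound 2 to compound 4 (within the scatter). Compound 4 is therefore estimated at 2%, with a likely range from -8% to 12%.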

Compound 4, a percentage reported as inhibition, at one concentration (the size of the read-out at that concentration, not a potency): 5%
For compound 4 the middle estimate is 3 percentage points below the measured one; the range from low to high includes it.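

Chloro in place of hydrogen on an aromatic carbon gives a number 5 percentage points higher from compound 2 to compound 4 (within the scatter). Set beside the earlier step, the same change reads alike on the two cores: the same change on two cores in this assay, a number 3 percentage points higher (within the scatter) from compound 3 to compound 1 and a number 5 percentage points higher (within the scatter) from compound 2 to compound 4, 2 percentage points apart, within the scatter of two such steps. Among the compounds shown here, this shows only that the change stays within the scatter in this assay on both cores; it does not show that chloro raises the effect, and with all four compounds at low readings, it says little about whether a larger effect would carry from one core to the other.

The compounds shown carry only hydrogen or chloro at this place on the aromatic ring, which leaves open what a methoxy group, an amine or a carboxylic acid would do there on either core. Also open, on these data alone, is whether any compound can give a clearly higher reading at the one concentration tested, and whether the two cores would still match if one did.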